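The source may hold more compounds than are shown below. What is called first, only, known or untested is meant among the compounds shown, and "the series" means these compounds.

Compound 1 `CN(C)C(=O)c1cc2cnc(Nc3ccc(NC(=O)C4(C(=O)Nc5cccc(Cl)c5)CC4)cc3)nc2n1C1CCCC1` and compound 2 `CN(C)C(=O)c1cc2cnc(Nc3ccc(NC(=O)C4(C(=O)Nc5ccc(Cl)c(C(F)(F)F)c5)CC4)cc3)nc2n1C1CCCC1` share one core and differ only in the group on an amide-type nitrogen. In a functional assay on NCI-H460 cells (Homo sapiens) for inhibition, read by CCK-8 assay, with a stated time of 72 h, tested at 1 uM (on this read-out lower numbers stand for less inhibition of growth and higher numbers for more inhibition of growth at the one concentration tested), compound 1 gives 44% while compound 2 gives 2.1% and so holds the lower of the two numbers. Compound 3 `CN(C)C(=O)c1cc2cnc(Nc3ccc(NC(=O)C4(C(=O)Nc5ccc(O)cc5)CC4)cc3)nc2n1C1CCCC1` keeps the same core and changes that group again, with 4-hydroxyphenyl in place of 4-chloro-3-(trifluoromethyl)phenyl on an amide-type nitrogen. For the measured compounds named here, only one measured step bears on this change, and it is large: a number 41.9 percentage points lower from compound 1 to compound 2 (beyond the scatter). Compound 2 carries the 4-chloro-3-(trifluoromethyl)phenyl that compound 1 lacks, and compound 3 gives that group up too. That single step, read backwards, therefore points to a rise, probably of similar or smaller size. Going by the values given here, no tested compound carries 4-hydroxyphenyl, so the size remains uncertain. The expected change is a number 22.9 percentage points higher from compound 2 to compound 3 (beyond the scatter) in this direction. For compound 3 the estimated value is 25%, with an expected range from 5% to 55% in this assay.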

Compound 3, percent growth inhibition at one concentration: 90.4%
Beside the measured number, compound 3's estimate is 65.4 percentage points below it; the measured number lies above the stated range.
By their numbers in this assay, from the lowest: compound 2; then compound 1; then compound 3.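

In this assay, 4-hydroxyphenyl on the amide-type nitrogen in place of 4-chloro-3-(trifluoromethyl)phenyl gives a number 88.3 percentage points higher from compound 2 to compound 3 (beyond the scatter), and in place of 3-chlorophenyl it gives a number 46.4 percentage points higher from compound 1 to compound 3 (beyond the scatter), so compound 1 does not mark the upper end of what this position can reach. All three groups have a six-membered aromatic ring of carbon only, so these large differences arise among compounds that differ in what is attached to that ring, not in the ring itself. No measurement shown here explains why the group with the hydroxy substituent stands so far above the two groups with chlorine.

The compounds shown leave open whether the hydroxy group itself matters or whether removing chlorine and trifluoromethyl is enough, a question that plain phenyl, 4-methoxyphenyl or 4-aminophenyl at this position could help to separate. They also leave open how these compounds would rank across a range of concentrations, since this read-out reports growth inhibition at a single concentration.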